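Efficacy notes on arylacetamide-piperidine series at the dopamine D4 receptor

The compounds below may be only part of what the source reports. "The series", "measured", "known", "first", "only" and "open" are said of these compounds alone.

Measured compounds:
- compound 1 `COc1cccc(C)c1NC(=O)CN1CCC(c2cccc[n+]2[O-])CC1`: 56%
- compound 2 `Cc1cc(Br)ccc1NC(=O)CN1CCC(c2cccc[n+]2[O-])CC1`: 61%
- compound 3 `Cc1cc(Cl)cc(C)c1NC(=O)CN1CCC(c2ccccn2)CC1`: 50%

The read-out throughout is a functional assay on HEK293 cells for agonist activity at D(4) dopamine receptor (Homo sapiens), read by FLIPR; a higher number here means a larger maximal response, a lower number a smaller maximal response. Compound 2 gives the highest of the three numbers, 61%. Compound 1 is the nearest, at 56%, which lies within the scatter of compound 2, so no order between these two can be claimed. Compound 3, at 50%, sits beyond the scatter below compound 2.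

Compound 4 `Cc1cccc(C)c1NC(=O)CN1CCC(c2cccc[n+]2[O-])CC1` is not yet measured in this assay. It differs from compound 2 in one place: 2,6-dimethylphenyl in place of 4-bromo-2-methylphenyl on an amide-type nitrogen. Compound 1 and compound 3, each carrying two substituents flanking the amide-bearing ring carbon in their own way, give the two lower numbers, and compound 3 in particular lies beyond the scatter below compound 2. On that basis a small downward step is expected from compound 2 to compound 4, a number 8 percentage points lower from compound 2 to compound 4 (within the scatter), probably not beyond the scatter. The estimate for compound 4 in this assay is 53%, with a range from 40% to 66%.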

Compound 4, largest response reached (reported as efficacy), in percent of the reference or control that the assay uses: 68%
The estimate for compound 4 lay 15 percentage points below the measured number; the whole stated range lies below it.
By their numbers in this assay, from the lowest: compounds 3, 1, 2 and 4 (each within the scatter of the next, the first and the last beyond it).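

In this assay the change on the amide-type nitrogen from 4-bromo-2-methylphenyl to 2,6-dimethylphenyl stays within the scatter (a number 7 percentage points higher from compound 2 to compound 4 (within the scatter)), so the two groups cannot be told apart at this place. Methyl in place of methoxy on an aromatic carbon, by contrast, gives a modest step beyond the scatter (a number 12 percentage points higher from compound 1 to compound 4 (beyond the scatter)), the first sign that a single exchange on this aryl group can shift the maximal response. Nothing available accounts for either step.

The compounds shown leave open how an ethyl, a hydroxyl or an amine would read in place of that methyl, and whether an unsubstituted phenyl on the amide-type nitrogen would hold the response. Compound 3 has no one-place partner here, so its value cannot yet be tied to any single change.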